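The source may hold more compounds than are shown below. What is called first, only, known or untested is meant among the compounds shown, and "the series" means these compounds.

Compound 1 `Cc1ccc2c(NCc3ccc(NC(=O)C4CCN(Cc5ncc[nH]5)CC4)cc3)nc(N(C)C)nc2c1`: > 20000 nM in a functional assay on SV5A8 cells (Homo sapiens) for cytotoxicity; a higher number here means a weaker inhibitor, a lower number a stronger inhibitor
Compound 2 `Cc1ccc2c(NCc3ccc(NC(=O)C4CCN(Cc5ccccc5)CC4)cc3)nc(N(C)CCN(C)C)nc2c1`: > 8830 nM in this assay

Compound 1 gives > 20000 nM in this assay, which is a limit of the assay rather than a number. Compound 2 gives > 8830 nM in this assay, again only a limit. So compound 1 stands at the limit described by the limit of > 20000 nM in this assay, at which 1 of the 2 values shown sits, and compound 2 sits at the one described by the limit of > 8830 nM in this assay, at which 1 of the 2 values shown sits; neither offers a number that could be compared with the other. Compound 3 `Cc1ccc2c(NCc3ccc(NC(=O)C4CCN(CC5CCNCC5)CC4)cc3)nc(N(C)C)nc2c1` differs from compound 1 in one place: piperidin-4-yl in place of 1H-imidazol-2-yl on a saturated chain carbon bound to an amine nitrogen in a ring. Going by the values given here, no measured step between two compounds exists here, so the effect of this change can only be anticipated from where compound 1 stands. Compound 3 is expected to show a step that the limit leaves unreadable from compound 1 to compound 3, none beyond the scatter, because compound 1 already sits at the limit of > 20000 nM in this assay, at which 1 of the 2 values shown sits. Compound 3 is therefore estimated at 30000 nM, with a range from 5000 nM to 200000 nM.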

Compound 3, half-maximal inhibitory concentration: > 8070 nM
Compound 3 was reported as a limit; the forecaster's own chance of this, stated with the estimate: 80%; the middle value does not contradict the limit.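

Compound 1 and compound 3 both give only limits of the assay rather than numbers in this assay, so no step can be read from replacing 1H-imidazol-2-yl with piperidin-4-yl. The compounds shown leave open whether this change alters the cytotoxicity at all.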